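Methoxy in Place of Fluoro: an Expected Cytotoxicity

The compounds below may be only part of what the source reports. "The series", "measured", "known", "first", "only" and "open" are said of these compounds alone.

Of the compounds shown here, three have so far been tested in an ADME assay on HepG2 cells (Homo sapiens) for cytotoxicity, read by MTT assay, with a stated time of 48 h; on this read-out higher numbers stand for lower toxicity in this test and lower numbers for higher toxicity in this test. Compound 1 `C#CCN(c1nc(-c2cccc([N+](=O)[O-])c2)no1)C1CCCCC1` gives 45.5 ug/mL. Compound 2 `CC(=O)OC[C@H]1O[C@H](OC[C@H](Cn2cc(COc3ccc(-c4noc(C)n4)cc3)nn2)OC(C)=O)C=C[C@@H]1OC(C)=O` gives 37.7 ug/mL. Compound 3 `CC(=O)OC[C@H]1O[C@H](OC[C@@H](Cn2cc(CN(c3nc(-c4ccc(F)cc4)no3)C3CCCCC3)nn2)OC(C)=O)C=C[C@@H]1OC(C)=O` gives 28.8 ug/mL, which is the lowest of the three numbers, yet its distance from compound 2 and from compound 1 both fall within the usual scatter of repeated measurements, so the three compounds read as alike rather than as a ranked series.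

Compound 4 `COc1ccc(-c2noc(N(Cc3cn(C[C@H](CO[C@@H]4C=C[C@H](OC(C)=O)[C@@H](COC(C)=O)O4)OC(C)=O)nn3)C3CCCCC3)n2)cc1` has not yet been measured. It differs from compound 3 in a single place: methoxy in place of fluoro on an aromatic carbon. Going by the values given here, no pair of measured compounds shows this same exchange, so there is no measured step to lean on, and the three measured values are themselves so close that they give no direction. In this assay a change of this size, a small group swapped for another small group without a ring, is expected to move the number little, if at all, beyond the scatter.

Compound 4 is therefore estimated at 30 ug/mL, with a range from 15 ug/mL to 60 ug/mL. The expected step of a 1.0-fold higher number from compound 3 to compound 4 (0.02 log units; within the scatter) is essentially none beyond the scatter.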

Compound 4, half-maximal cytotoxic concentration: 141 ug/mL
Beside the measured number, compound 4's estimate is 4.7-fold (0.67 log units) below it; measured number above the stated range.
By their numbers in this assay, from the lowest: compounds 3, 2 and 1 (each within the scatter of the next); then compound 4.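

In this assay, going from 4-fluorophenyl to 4-methoxyphenyl gives a 4.9-fold higher number from compound 3 to compound 4 (0.69 log units; beyond the scatter), a shift toward lower toxicity in this test. Going by these compounds alone, this is the first one-place comparison in the set, and it shows that this position, para to a large group on the six-membered aromatic ring, can move the read-out beyond the scatter even when one small group without a ring replaces another. No measurement shown here accounts for the size or direction of this step.

A single pair cannot show whether the shift follows the oxygen of the methoxy group, its carbon, or the loss of fluoro; hydroxy, methyl or an amine at the same position would help separate these. Going by these compounds, whether the same exchange acts similarly on a different core also remains open.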